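A few compounds are considered here, and "the series" means these few. Any claim that something is new, unique, unknown or untested is made for them only; others in the source may bear on it.

Measured in an assay for inhibition of 3-hydroxy-3-methylglutaryl-coenzyme A reductase (Rattus norvegicus); a lower number here means a stronger inhibitor, a higher number a weaker inhibitor:
compound 1 `COc1ccc(-c2cc(Cl)cc(Cl)c2/C=C/[C@@H]2C[C@@H](O)CC(=O)O2)cc1` gives 470 nM
compound 2 `Cc1ccccc1-c1cc(Cl)cc(Cl)c1/C=C/[C@@H]1C[C@@H](O)CC(=O)O1` gives 370 nM

Of these two, compound 2 holds the lower number, though its gap to compound 1 lies within the scatter. Compound 3 `CCc1cccc(-c2cc(Cl)cc(Cl)c2/C=C/[C@@H]2C[C@@H](O)CC(=O)O2)c1` is not yet measured. It differs from compound 2 in one place: 3-ethylphenyl in place of 2-methylphenyl on an aromatic carbon. Among the measured compounds shown here, the one measured step that bears on this position, a 1.3-fold lower number from compound 1 to compound 2 (0.10 log units; within the scatter), swapped one aryl group for another on the same aromatic carbon and stayed within the scatter. A similar outcome is therefore expected for no change at the digits printed from compound 2 to compound 3 (within the scatter), with no movement beyond the scatter. Compound 3 is accordingly estimated at 370 nM, in the range 150 nM to 900 nM.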

Compound 3, half-maximal inhibitory concentration: 44 nM
For compound 3 the middle estimate is 8.4-fold (0.92 log units) above the measured one, outside the stated range (below it).
By their numbers in this assay, from the lowest: compound 3; then compounds 2 and 1 (each within the scatter of the next).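

The change brings an 8.4-fold lower number from compound 2 to compound 3 (0.92 log units; beyond the scatter) and an 11-fold lower number from compound 1 to compound 3 (1.03 log units; beyond the scatter) in this assay once 3-ethylphenyl sits on this aromatic carbon. The earlier exchange of one aryl group for another stayed within the scatter, so only now does this position prove responsive to the choice of aryl group. Nothing measured here accounts for the gain.

Compound 3 differs from compound 2 in both the alkyl chain and its place on the phenyl ring, so these two changes cannot be separated. As far as these compounds go, how a 3-methylphenyl, a 3-propylphenyl or a phenyl bearing an amine would compare remains open.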